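The source may report more compounds than this note shows. Statements on the series, on what has been measured and on what is new or still open speak of the compounds shown alone.

Two compounds of the series have numbers in a functional assay on cells (Cancer cell lines, Homo sapiens) for cytotoxicity, with a stated time of 48 h; a lower number here means a stronger inhibitor of growth, a higher number a weaker inhibitor of growth. Compound 1 `COc1c(/C=C2/C(=O)Nc3ccc(Cl)cc32)c2ccccc2n1-c1ccccc1` gives 8510 nM in this assay. Going by the values given here, compound 2 `COc1cc2c(/C=C3/C(=O)Nc4ccc(O)cc43)c(Cl)n(Cc3cc(OC)c(OC)c(OC)c3)c2cc1C` gives 2750 nM in this assay, the lower of the two numbers; the two structures differ in several places at once, so no single step joins them, and the gap by which compound 1 stands above compound 2 lies beyond the scatter. Compound 3 `COc1cc2c(/C=C3/C(=O)Nc4ccc(Cl)cc43)c(Cl)n(Cc3cc(OC)c(OC)c(OC)c3)c2cc1C` is the next member and has not been measured in this assay. It differs from compound 2 in one place: chloro in place of hydroxy on an aromatic carbon. Among the compounds with values here, no pair of measured compounds differs in just this group, so the size of this change is not known from the data. Compound 1 also carries chloro rather than hydroxy on its core and stands at 8510 nM, but its other differences from compound 2 leave that number a weak guide. A modest step toward a higher number is expected, a 1.6-fold higher number from compound 2 to compound 3 (0.21 log units; within the scatter), with a wide range. Compound 3 is expected to give 4500 nM in this assay, within 1400 nM to 14000 nM.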

Compound 3, concentration for 50% growth inhibition: 2950 nM
Estimate against measurement, compound 3: 1.5-fold (0.18 log units) above, within the range that was stated.
By their numbers in this assay, from the lowest: compounds 2 and 3 (each within the scatter of the next); then compound 1.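

In this assay, chloro in place of hydroxy on an aromatic carbon of the shared core, at the place meta to a fused ring and para to a fused ring, gives a 1.1-fold higher number from compound 2 to compound 3 (0.03 log units; within the scatter), and the two groups cannot be told apart at this position. Going by these compounds alone, this is the first reading of this change on its own: the earlier pair differs in several places at once and gave no size for it, whereas here the hydrogen-bond donor and acceptor counted for hydroxy are absent from chloro with no difference beyond the scatter in this background. No measured evidence bears on why the two groups read alike.

From the compounds shown here alone, this rests on a single step in one background, and whether it carries over to the core of compound 1 remains open. Going by these compounds, how an amine, a carboxylic acid or a longer chain such as an ethoxy group would read at this same position also remains open, and with it how much this position tolerates beyond hydroxy and chloro.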